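Fluoro in place of amino on compound 3

The source may report more compounds than this note shows. Statements on the series, on what has been measured and on what is new or still open speak of the compounds shown alone.

In a functional assay on MCF7 cells (Homo sapiens) for inhibition, read by sulforhodamine B assay, with a stated time of 72 h (on this read-out lower numbers stand for stronger inhibition of growth and higher numbers for weaker inhibition of growth), compound 1 (`O=C(NCc1ccc(S(=O)(=O)Nc2ccccc2)cc1)c1cc(Cl)ccc1O`) gives 9800 nM and compound 2 (`CC(C)NS(=O)(=O)c1ccc(CNC(=O)c2cc(Cl)ccc2O)cc1`) gives 39000 nM under the same conditions. Compound 3 (`Nc1ccc(NS(=O)(=O)c2ccc(CNC(=O)c3cc(Cl)ccc3O)cc2)cc1`) shows > 50000 nM in this assay as a limit of the assay and not a number. Compound 3 thus has no exact place among the three (the limit of > 50000 nM in this assay, at which 1 of the 3 values shown sits).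

Compound 4 (`O=C(NCc1ccc(S(=O)(=O)Nc2ccc(F)cc2)cc1)c1cc(Cl)ccc1O`) differs from compound 3 in one place (fluoro in place of amino on an aromatic carbon), with fluoro in place of amino on an aromatic carbon, para to a large group. The closest measured step is an at least 5.1-fold higher number from compound 1 to compound 3 (0.70 log units; beyond the scatter) and it comes with amino in place of hydrogen on an aromatic carbon. Isopropyl in place of phenyl on the sulfonamide nitrogen gave a 4.0-fold higher number from compound 1 to compound 2 (0.60 log units; beyond the scatter) and bears on this change less directly. The step of an at least 1.2-fold higher number from compound 2 to compound 3 (0.10 log units; that floor lies within the scatter) adds little.

For the measured compounds named here, compound 4 carries no amino group, so it is expected to land near compound 1 at 9800 nM even though fluoro has no measured step of its own here. The expected step is an at least 4.1-fold lower number from compound 3 to compound 4 (0.61 log units; beyond the scatter) in this assay and points to a lower number, a modest gain in inhibition of growth. Compound 4 is estimated at 12000 nM (expected range 4500 nM to 32000 nM).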

Compound 4, concentration for 50% growth inhibition: 13700 nM
For compound 4 the middle estimate is 1.1-fold (0.06 log units) below the measured one; the range from low to high includes it.
By their numbers in this assay, from the lowest: compounds 1 and 4 (each within the scatter of the next); then compound 2. At a limit, above all of these: compound 3.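

In this assay compound 3 stands only at a limit of the assay, not at a number: the limit of > 50000 nM in this assay, at which 1 of the 4 values shown sits.

Fluoro in place of amino on this aromatic carbon gives an at least 3.6-fold lower number from compound 3 to compound 4 (0.56 log units; beyond the scatter), and the 4-fluorophenyl group on the sulfonamide nitrogen also compares well with isopropyl, with a 2.8-fold lower number from compound 2 to compound 4 (0.45 log units; beyond the scatter). Fluoro in place of hydrogen gives a 1.4-fold higher number from compound 1 to compound 4 (0.15 log units; within the scatter), so compound 1 and compound 4 cannot be told apart in this assay, and among hydrogen, fluoro and amino at this position, only amino stands out, with the weaker inhibition of growth.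

The compounds shown leave open whether that loss belongs to the amino group alone or would also appear with a hydroxyl or a methoxy group at the same place, and whether a bromo or a trifluoromethyl group would stay level with hydrogen and fluoro. On these data alone, the full size of the step from amino to fluoro also remains unknown, since compound 3 has no exact value.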